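Aryl in place of hexyl on the amine of compound 1

The source may hold more compounds than are shown below. What is called first, only, known or untested is meant among the compounds shown, and "the series" means these compounds.

Compound 1 `CCCCCCNc1nc(SCc2ccc(C(F)(F)F)cc2)nc2ccccc12` gives 20200 nM in a functional assay on MDA-MB-231 cells (Homo sapiens) for cytotoxicity, read by MTT assay, with a stated time of 72 h (a higher number here means a weaker inhibitor, a lower number a stronger inhibitor), the highest of the three numbers measured; its nearest neighbour is compound 2 `FC(F)(F)c1ccc(CSc2nc(Nc3cccc(C(F)(F)F)c3)c3ccccc3n2)cc1` at 11100 nM, and the furthest is compound 3 `FC(F)(F)c1ccc(CSc2nc(Nc3ccc(C(F)(F)F)cc3)c3ccccc3n2)cc1` at 5460 nM. Compound 4 `COc1ccc(Nc2nc(SCc3ccc(C(F)(F)F)cc3)nc3ccccc23)c(OC)c1` differs from compound 1 in one place: 2,4-dimethoxyphenyl in place of hexyl on a nitrogen on an aromatic ring. Among the compounds with values here, two measured steps bear on this change, since both also put a substituted phenyl in place of hexyl on the same nitrogen: a 1.8-fold lower number from compound 1 to compound 2 (0.26 log units; within the scatter) and a 3.7-fold lower number from compound 1 to compound 3 (0.57 log units; beyond the scatter). The first lies within the scatter, the second beyond it, and the two aryl groups differ from each other by a 2.0-fold lower number from compound 2 to compound 3 (0.31 log units; beyond the scatter). Within the data shown here, on this basis a modest lowering of the number in this assay is expected for compound 4, though no measured compound carries methoxy groups, so the size is uncertain. The estimate for compound 4 is 8000 nM, with a range from 3000 nM to 22000 nM, which corresponds to an expected step of a 2.5-fold lower number from compound 1 to compound 4 (0.40 log units; beyond the scatter).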

Compound 4, half-maximal inhibitory concentration: > 50000 nM
Compound 4: only a limit was reported; the forecaster's own chance of this, stated with the estimate: 10%; middle value at least 6.2-fold (0.79 log units) away from the limit.
By their numbers in this assay, from the lowest: compound 3; then compounds 2 and 1 (each within the scatter of the next). At a limit, above all of these: compound 4.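

In this assay, the reading for compound 4 is a limit of the assay and not a number: the limit of > 50000 nM in this assay, at which 1 of the 4 values shown sits. It shows that an aryl group on this nitrogen does not in itself lower the number, since 2,4-dimethoxyphenyl in place of hexyl gives an at least 2.4-fold higher number from compound 1 to compound 4 (0.39 log units; beyond the scatter), against the opposite direction of a 3.7-fold lower number from compound 1 to compound 3 (0.57 log units; beyond the scatter). The substituents on the phenyl ring also count for more than the two trifluoromethylphenyl compounds alone could show, with an at least 9.1-fold higher number from compound 3 to compound 4 (0.96 log units; beyond the scatter) and an at least 4.5-fold higher number from compound 2 to compound 4 (0.65 log units; beyond the scatter), both wider than a 2.0-fold lower number from compound 2 to compound 3 (0.31 log units; beyond the scatter).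

The compounds shown leave open whether a single methoxy group would give the same result or whether the change takes both. They also leave open how an unsubstituted phenyl, a 4-chlorophenyl or a shorter chain such as butyl would read on this nitrogen.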